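The source may hold more compounds than are shown below. What is called first, only, known or untested is meant among the compounds shown, and "the series" means these compounds.

Compound 2 `O=C(/C=C/c1ccc2c(c1)B(O)OC2)c1ccc(F)cc1` gives 7600 nM in a toxicity assay on WI-38 cells (Homo sapiens) for cytotoxicity, read by MTT assay, with a stated time of 48 h (a higher number here means a weaker inhibitor, a lower number a stronger inhibitor), the lowest of the two numbers shown. Compound 1 `O=C(/C=C/c1ccc2c(c1)B(O)OC2)c1ccco1` gives 59000 nM in this assay, and the step of a 7.8-fold lower number from compound 1 to compound 2 (0.89 log units; beyond the scatter) goes with 4-fluorophenyl in place of furan-2-yl on a carbonyl carbon. Compound 3 `O=C(/C=C/c1ccc2c(c1)B(O)OC2)c1ccc(OCc2ccccc2)cc1` reaches only the limit > 100000 nM in this assay. The step of an at least 13-fold higher number from compound 2 to compound 3 (1.11 log units; beyond the scatter) is large. At the limit of > 100000 nM in this assay, at which 1 of the 3 values shown sits, the assay reports no number. Compound 4 `O=C(/C=C/c1ccc2c(c1)B(O)OC2)c1cccc(F)c1` differs from compound 2 by 3-fluorophenyl in place of 4-fluorophenyl on a carbonyl carbon. Both measured steps change what the carbonyl carbon carries, yet neither moves a fluorine within its ring, so this smaller change is expected to give a step of a 1.2-fold higher number from compound 2 to compound 4 (0.07 log units; within the scatter), within the scatter. Compound 4 is therefore expected to give 9000 nM, between 3000 nM and 30000 nM.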

Compound 4, half-maximal inhibitory concentration: 26700 nM
Estimate against measurement, compound 4: 3.0-fold (0.47 log units) below, within the range that was stated.
By their numbers in this assay, from the lowest: compound 2; then compound 4; then compound 1. At a limit, above all of these: compound 3.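

Moving the fluorine alone, with the same atoms on the carbonyl carbon, shifts the reading in this assay (a 3.5-fold higher number from compound 2 to compound 4 (0.55 log units; beyond the scatter)). The result therefore depends on where the fluorine sits and not only on which ring is present, and 3-fluorophenyl keeps a smaller part of the gain over furan-2-yl (a 2.2-fold lower number from compound 1 to compound 4 (0.34 log units; beyond the scatter)). Nothing given here accounts for this shift. As far as these compounds go, it remains open whether a chlorophenyl or an aminophenyl group on the carbonyl carbon would follow compound 2 or compound 4.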